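This account rests on a few compounds, and the source may have more. Where it says the series, first, only, none or still open, it means among the compounds named here.

Measured compounds:
compound 1, `CC(C)CSc1nc(N)nc2c1ncn2/C=C1/CC1(CO)CO` — "not determined" (no result reported)
compound 2, `CSc1nc(N)nc2c1ncn2/C=C1/CC1(CO)CO` — > 20000 nM
compound 3, `CCCCCOc1nc(N)nc2c1ncn2/C=C1/CC1(CO)CO` — > 20000 nM

In an ADME assay on MOLT-3 cells (Homo sapiens) for cytotoxicity, with a stated time of 7 days (on this read-out lower numbers stand for higher toxicity in this test and higher numbers for lower toxicity in this test), compound 1 gives "not determined" (no result reported), so it carries no number of its own on this read-out. Compound 2 sits at > 20000 nM, a limit of the assay rather than a number. Compound 3 likewise sits at > 20000 nM, again a limit. Among the measured compounds shown here, the only step within the measured set, a step that the two limits leave unreadable from compound 2 to compound 3, therefore cannot be read in either direction. What the measured values do show is the limit of > 20000 nM in this assay, at which 2 of the 3 values shown sit.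

Compound 4, `CC(C)Sc1nc(N)nc2c1ncn2/C=C1/CC1(CO)CO`, differs from compound 1 by isopropyl in place of isobutyl on a sulfur. For the measured compounds named here, no measured step touches this exchange: the one recorded step swaps a group on an aromatic carbon, whereas here the sulfur keeps its place and only the alkyl on it changes. The shared core is common to all four compounds. With compound 1 unmeasured and both measured values sitting at the same limit, no size or direction can be drawn for the step from compound 1 to compound 4 in this assay; the working expectation is that compound 4 also lands at that limit. Compound 4 is expected at 25000 nM, with a range of 8000 nM to 60000 nM.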

Compound 4, half-maximal cytotoxic concentration: > 20000 nM
Compound 4 ended at the assay's limit (the forecaster's own chance of this, stated with the estimate: 80%); the middle value lies beyond the limit too.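

In this assay compound 4 sits at > 20000 nM, a limit of the assay and not a number. No new step can be read: the steps joining compound 4 to compound 2 and compound 3 run from limit to limit, giving neither size nor direction. The compounds shown leave open what actual values compound 2, compound 3 and compound 4 have, and how compound 1 compares with them.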